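Swapping a methyl for an amino on a quinoline amide

The source may report more compounds than this note shows. Statements on the series, on what has been measured and on what is new or still open speak of the compounds shown alone.

Measured so far:
Compound 1 `Cc1ccc(-c2cc(C(=O)N3CCC4(CC3)CC(=O)c3nn(C(C)(C)C)cc3O4)c3ccccc3n2)cc1` — > 10000 nM
Compound 2 `CC(C)(C)n1cc2c(n1)C(=O)CC1(CCN(C(=O)c3cc(-c4ccccc4Cl)nc4ccccc34)CC1)O2` — > 10000 nM

Compound 1 carries a 4-methylphenyl group on the shared core. In a functional assay on MDA-MB-231 cells (Homo sapiens) for inhibition, read by MTT assay, with a stated time of 72 h (a lower number here means a stronger inhibitor, a higher number a weaker inhibitor), compound 1 gives > 10000 nM, which is a limit of the assay rather than a measured number. Compound 2 differs from it only by 2-chlorophenyl in place of 4-methylphenyl on an aromatic carbon. In this assay compound 2 gives > 10000 nM, again a limit. The step that the two limits leave unreadable from compound 1 to compound 2 therefore cannot be read, because both compounds sit at the limit of > 10000 nM in this assay, at which 2 of the 2 values shown sit.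

Compound 3 `CC(C)(C)n1cc2c(n1)C(=O)CC1(CCN(C(=O)c3cc(-c4ccc(N)cc4)nc4ccccc34)CC1)O2` is not yet measured. It differs from compound 1 by amino in place of methyl on an aromatic carbon. Among the compounds with values here, the measured pair offers no readable step, so there is nothing to anchor a direction: the only evidence is that two variations of this aryl group both failed to show inhibition within the range of the assay. Compound 3 is therefore expected to give 15000 nM, with a range from 3000 nM to 60000 nM, most likely appearing again as a limit. This corresponds to an estimated step that the limit leaves unreadable from compound 1 to compound 3, meaning no change beyond the scatter is expected.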

Compound 3, half-maximal inhibitory concentration: 4960 nM
For compound 3 the middle estimate is 3.0-fold (0.48 log units) above the measured one, and the stated range covers the measured number.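

In this assay, compound 3 is the only one of the three that gives a measured number rather than a limit, so a change at this single place, para to a large group, can bring the reading into the range the assay can measure. Amino in place of methyl comes with an at least 2.0-fold lower number from compound 1 to compound 3 (0.30 log units; that floor lies within the scatter), and 4-aminophenyl in place of 2-chlorophenyl comes with an at least 2.0-fold lower number from compound 2 to compound 3 (0.30 log units; that floor lies within the scatter). Each of these is a floor and not a true size, because compound 1 and compound 2 give only a limit: the limit of > 10000 nM in this assay, at which 2 of the 3 values shown sit.

The compounds shown leave open whether this reading is particular to the amino group or would also appear with another group at the same place, such as a hydroxyl, a dimethylamino or an acetamide. They also leave open how large either step really is, and whether an amino group elsewhere on this six-membered aromatic ring would give a measured number too.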